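A few compounds are considered here, and "the series" means these few. Any claim that something is new, unique, unknown or untested is made for them only; others in the source may bear on it.

Measured compounds:
compound 1 `Cn1c(-c2cccc(Cl)c2)nc2c(NC3CCCC3)ncnc21` — 514 nM
compound 2 `Cc1ccc(-c2nc3c(NC4CCCC4)ncnc3n2C)cc1` — 480 nM
compound 3 `Cc1ccccc1-c1nc2c(NC3CCCC3)ncnc2n1C` — 3000 nM

These three share one core and differ only in the aryl group attached to it. In an assay on CHO cells for displacement of a labelled ligand from adenosine receptor A3 (Homo sapiens), read by scintillation counting, with a stated time of 3 h (on this read-out higher numbers stand for weaker inhibition and lower numbers for stronger inhibition), compound 3 has the highest number of the three. Its nearest neighbour is compound 1, and the step of a 5.8-fold higher number from compound 1 to compound 3 (0.77 log units; beyond the scatter) was modest but beyond the scatter; the step of a 6.3-fold higher number from compound 2 to compound 3 (0.80 log units; beyond the scatter) was of about the same size. Compound 1 and compound 2, with 3-chlorophenyl and 4-methylphenyl, sit within the scatter of each other, as the step of a 1.1-fold lower number from compound 1 to compound 2 (0.03 log units; within the scatter) shows.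

Compound 4 `Cc1cccc(-c2nc3c(NC4CCCC4)ncnc3n2C)c1` has not yet been measured. It differs from compound 3 in one place: 3-methylphenyl in place of 2-methylphenyl on an aromatic carbon. Both measured steps that bear on this move of the methyl group went in the same direction, so a modest step back toward the numbers of compound 1 and compound 2 is expected in this assay, that is, a lower number, as the expected step of a 5.5-fold lower number from compound 3 to compound 4 (0.74 log units; beyond the scatter) puts it. Compound 4 is therefore estimated at 550 nM, with a range from 200 nM to 1600 nM.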

Compound 4, inhibition constant: 510 nM
Compound 4: middle estimate off by 1.1-fold (0.03 log units), on the high side, within the range that was stated.
By their numbers in this assay, from the lowest: compounds 2, 4 and 1 (each within the scatter of the next); then compound 3.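

In this assay, the two groups have the same atoms and sit on the same aromatic carbon of the shared core, yet 3-methylphenyl in place of 2-methylphenyl gives a 5.9-fold lower number from compound 3 to compound 4 (0.77 log units; beyond the scatter), so where the methyl sits on the phenyl ring matters in this series. Moving it on to 4-methylphenyl brings no further change, with a 1.1-fold higher number from compound 2 to compound 4 (0.03 log units; within the scatter), which leaves 2-methylphenyl as the one group apart among those shown. Exchanging the methyl of 3-methylphenyl for the chloro of 3-chlorophenyl also makes no difference that can be read, with a 1.0-fold lower number from compound 1 to compound 4 (0.00 log units; within the scatter) as the step.

Nothing available here explains why the 2-methylphenyl group stands apart. Going by these compounds, it also remains open whether 2-chlorophenyl would show the same gap, and whether a methoxy group, an amine or a carboxylic acid on the phenyl ring would fit the same picture.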